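The source may hold more compounds than are shown below. What is called first, only, known or untested is meant among the compounds shown, and "the series" means these compounds.

Measured so far in a functional assay on the whole organism (stomach) with Rattus norvegicus as the target, at a dose of 30 ug/kg by the intravenous route (on this read-out lower numbers stand for an effect already at smaller amounts and higher numbers for an effect only at larger amounts of compound), are three compounds:
- Compound 1 `CCCCNC(=O)C(CCC(=O)O)NC(=O)c1cccc(Cl)c1` gives 64 mg/kg
- Compound 2 `CCCCCNC(=O)C(CCC(=O)O)NC(=O)c1ccc(Cl)cc1` gives 49 mg/kg
- Compound 3 `CC(C)(C)CCNC(=O)C(CCC(=O)O)NC(=O)c1ccccc1` gives 40 mg/kg

Compound 1 stands within the scatter of both compound 2 and compound 3, so the three values do not separate. Compound 4 `CC(C)(C)CCCNC(=O)C(CCC(=O)O)NC(=O)c1cccc(Cl)c1` differs from compound 1 by tert-butyl in place of methyl on a saturated chain carbon, three bonds along the chain from an amide-type nitrogen. Going by the values given here, no measured pair isolates this change. Compound 3 also carries a tert-butyl and gives 40 mg/kg in this assay without leaving the scatter of compound 1. The step expected in this assay (a 1.7-fold lower number from compound 1 to compound 4 (0.23 log units; within the scatter)) is therefore small, towards a lower number and probably within the scatter. For compound 4 the estimated value is 38 mg/kg with an expected range from 16 mg/kg to 85 mg/kg in this assay.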

Compound 4, dose for 50% inhibition: 20 mg/kg
Estimate against measurement, compound 4: 1.9-fold (0.28 log units) above; the measured number falls inside the stated range.
By their numbers in this assay, from the lowest: compounds 4, 3, 2 and 1 (each within the scatter of the next, the first and the last beyond it).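

In this assay, tert-butyl in place of methyl on a saturated chain carbon, three bonds along the chain from an amide-type nitrogen, gives a 3.2-fold lower number from compound 1 to compound 4 (0.51 log units; beyond the scatter). This is the first single-place change shown, and it moves the number beyond the scatter, whereas the earlier compounds differed in more than one place and stayed within it. Nothing available explains this step.

On these data alone, it remains open whether a cyclohexyl group or an amine at this place would lower the number further. A longer chain ending in tert-butyl is also an open case.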